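This account rests on a few compounds, and the source may have more. Where it says the series, first, only, none or still open, it means among the compounds named here.

Measured so far in a functional assay for antagonist activity at Neuropeptide Y receptor type 5 (Homo sapiens); a lower number here means a stronger inhibitor, a higher number a weaker inhibitor:
- compound 1 `O=C1O[C@]2(CC[C@H](CNc3ccc(-c4ncccn4)cn3)CC2)CN1c1ccccn1` gives 0.159 nM
- compound 2 `O=C1O[C@]2(CC[C@H](CNc3ccc(-c4nccs4)cn3)CC2)CN1c1ccccn1` gives 0.126 nM

Going by the values given here, compound 2 carries the lowest of the two numbers in this assay, with compound 1 next; the one measured step, a 1.3-fold lower number from compound 1 to compound 2 (0.10 log units; within the scatter), lies within the scatter, so the two compounds cannot be separated.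

Compound 3 `O=C1O[C@]2(CC[C@H](CNc3ccc(OC4CCC4)cn3)CC2)CN1c1ccccn1` is not yet measured. It differs from compound 2 by cyclobutyloxy in place of 1,3-thiazol-2-yl on an aromatic carbon. Among the compounds with values here, the only measured step, a 1.3-fold lower number from compound 1 to compound 2 (0.10 log units; within the scatter), exchanges one five-membered aromatic ring for a six-membered aromatic ring at the same carbon and is flat; it bears on the present change only loosely, since here a non-aromatic cyclobutyloxy with a single acceptor enters. Within the data shown here, no measured pair shows what such an exchange does. The expected step is therefore a modest loss, a 3.2-fold higher number from compound 2 to compound 3 (0.50 log units; beyond the scatter), with wide uncertainty in both directions.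

For compound 3 the estimated value in this assay is 0.4 nM, within a range from 0.1 nM to 1.6 nM.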

Compound 3, inhibition constant: 0.159 nM
For compound 3 the middle estimate is 2.5-fold (0.40 log units) above the measured one; low and high end bracket the measured number.
By their numbers in this assay, from the lowest: compounds 2, 1 and 3 (each within the scatter of the next).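

In this assay, the place on the aromatic carbon para to a large group is not limited to aromatic rings among these compounds: cyclobutyloxy, a four-membered non-aromatic ring of carbon only attached through oxygen, gives a 1.3-fold higher number from compound 2 to compound 3 (0.10 log units; within the scatter), and against the six-membered aromatic ring it gives no change at the digits printed from compound 1 to compound 3 (within the scatter). Across compounds 1, 2 and 3, neither the loss of the aromatic ring nor the change from 2 hydrogen-bond acceptors in 1,3-thiazol-2-yl to 1 in cyclobutyloxy separates the values, so the three compounds stand as one group at this place. No measurement is available that accounts for this flat result.

The compounds shown leave open whether this place stays as flat with a group that carries a charge or a hydrogen-bond donor, such as a carboxylic acid or a primary amine. They also do not show whether an open-chain ether such as butoxy, or a larger ring such as cyclohexyloxy, would fit the same group or would finally produce a step beyond the scatter.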